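The source may hold more compounds than are shown below. What is called first, only, known or untested is meant among the compounds shown, and "the series" means these compounds.

Within the data shown here, compound 2 `Cc1ccc(S(=O)(=O)N[C@@H](CC(=O)NC(C)(C)C)C(=O)NCCNC(=O)c2cccc(C(C)C)c2)cc1` is one of two compounds measured in an ADME assay on HepG2 cells (Homo sapiens) for cytotoxicity; a higher number here means that more compound is needed for the effect, a lower number that less compound is needed; the other is compound 1 `Cc1ccc(S(=O)(=O)N[C@@H](CC(=O)NC(C)(C)C)C(=O)NCCNC(=O)NCc2ccccc2)cc1`. In this assay compound 1 reaches only the limit of the assay, > 11000 nM. In this assay compound 2 likewise stands at a limit, > 11000 nM, so its position is known only as a limit and not as a number. Among the measured compounds shown here, the single step among measured compounds, a step that the two limits leave unreadable from compound 1 to compound 2, is unreadable in size; both compounds sit at the limit of > 11000 nM in this assay, at which 2 of the 2 values shown sit. Compound 3 `Cc1ccc(S(=O)(=O)N[C@@H](CC(=O)NC(C)(C)C)C(=O)NCCNC(=O)c2cccc(C(F)(F)F)c2)cc1` differs from compound 2 by trifluoromethyl in place of isopropyl on an aromatic carbon. No measured step bears on this change, and the one step shown gives no size. Compound 3 is therefore expected to remain at the same limit, the step that the limit leaves unreadable from compound 2 to compound 3 being expected to stay within the scatter. The estimate for compound 3 in this assay is 15000 nM, with a range from 8000 nM to 40000 nM.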

Compound 3, half-maximal effective concentration: > 11000 nM
Compound 3 gave a limit, no number; the forecaster's own chance of this, stated with the estimate: 80%; the middle value is on the limit's open side.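

No new step can be read in this assay, since compound 3 stands with compound 1 and compound 2 at one limit: the limit of > 11000 nM in this assay, at which 3 of the 3 values shown sit.

The compounds shown leave open what concentration any of them needs for the effect, and whether trifluoromethyl in place of isopropyl changes it at all.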